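A few compounds are considered here, and "the series" means these few. Any claim that something is new, unique, unknown or untested is made for them only; others in the source may bear on it.

Compound 1: `O=C(CCCCCNc1c(Nc2ccccc2)c(=O)c1=O)NO`; in an ADME assay on cells (Hepatocyte, Homo sapiens) for pharmacokinetics, read by LC-MS, with a stated time of 90 min, tested at 1 uM (on this read-out lower numbers stand for slow clearance and higher numbers for fast clearance), compound 1 gives < 4.8 uL/min, which is a limit of the assay rather than a number.
Compound 2: `O=C(CCCCCNc1c(NCc2ccccc2)c(=O)c1=O)NO`; in this assay compound 2 gives < 4.8 uL/min, again a limit of the assay and not a number.

Both measured compounds therefore sit at the floor of what this assay can report, as the limit of < 4.8 uL/min in this assay, at which 2 of the 2 values shown sit, records. Within the data shown here, the only step measured between them, a step that the two limits leave unreadable from compound 1 to compound 2, brought benzyl in place of phenyl on a nitrogen on an aromatic ring. Both of its ends are limits, so its size cannot be read. Compound 2 thus stands at the limit, with nothing known about how far beneath it the true value lies.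

The next compound, compound 3 `C[C@@H](Nc1c(NCCCCCC(=O)NO)c(=O)c1=O)c1ccccc1`, differs from compound 2 by methyl in place of hydrogen on a saturated chain carbon bound to an aromatic carbon and a nitrogen on an aromatic ring. Among the measured compounds shown here, no measured step bears directly on this change; the one measured step, a step that the two limits leave unreadable from compound 1 to compound 2, varied the group on the ring nitrogen without reaching a readable number, so it gives no direction to carry forward. The expectation for compound 3 is that it stays close to where compound 2 stands, with a step that the limit leaves unreadable from compound 2 to compound 3 expected to lie within the usual scatter. Compound 3 is therefore estimated at 4 uL/min, within a range from 1.5 uL/min to 11 uL/min.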

Compound 3, intrinsic clearance in a liver preparation (reported as CLH), per the amount of preparation that the assay uses: < 5 uL/min
Compound 3 ended at the assay's limit; the forecaster's own chance of this, stated with the estimate: 55%; the middle value lies beyond the limit too.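

In this assay compound 3 gives < 5 uL/min, which is a limit of the assay and not a number. With limits at both ends, the steps among compound 1, compound 2 and compound 3 cannot be read. The compounds shown leave open how far beneath these limits the true values lie, and whether the added methyl changes clearance at all.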